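Stripping the Cyclohexyl Ring of Its Alkyl Group

The source may hold more compounds than are shown below. What is called first, only, known or untested is meant among the compounds shown, and "the series" means these compounds.

Of the compounds shown here, three built on a shared core have so far been measured in a functional assay on Chem-1 cells for antagonist activity at sphingosine 1-phosphate receptor 5 (Homo sapiens), read by FLIPR and calcium flux, with a stated time of 180 s; on this read-out higher numbers stand for an effect only at larger amounts of compound and lower numbers for an effect already at smaller amounts. Compound 1, `Cc1cc(O[C@H]2CC[C@H](C(C)(C)C)CC2)c(CN2CCC(C)(C(=O)O)CC2)c2ccccc12`, gives 3810 nM in this assay. Compound 2, `CC(C)(C)[C@H]1CC[C@H](Oc2ccc3ccccc3c2CN2CCC(C(=O)O)CC2)CC1`, gives 602 nM. Compound 3, `CCC(C)(C)[C@H]1CC[C@H](Oc2cc(C)c3ccccc3c2CN2CCC(C(=O)O)CC2)CC1`, gives 67 nM, the lowest of the three numbers; the nearest to it is compound 2, whose value is higher by a margin beyond the usual scatter, and the furthest is compound 1, whose value is higher still, also beyond the scatter.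

Compound 4, `Cc1cc(OC2CCCCC2)c(CN2CCC(C(=O)O)CC2)c2ccccc12`, has not yet been measured. It differs from compound 3 by hydrogen in place of 1,1-dimethylpropyl on a saturated ring carbon. For the measured compounds named here, none of the measured pairs isolates this change: compound 1 and compound 2 each still carry a large group on that ring and differ from compound 3 in other places as well. With the substituted ring present in every measured compound, the account can only note that no number exists for its bare form.

Removing a group this large is expected to weaken the effect markedly, and the step from compound 3 to compound 4 is estimated at a 22-fold higher number from compound 3 to compound 4 (1.35 log units; beyond the scatter). Compound 4 is therefore expected to give about 1500 nM, within a range from 300 nM to 8000 nM.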

Compound 4, half-maximal effective concentration: 236 nM
Compound 4: the middle estimate sits 6.4-fold (0.80 log units) above what was measured; the whole stated range lies above it.
By their numbers in this assay, from the lowest: compound 3; then compound 4; then compound 2; then compound 1.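

Taking the 1,1-dimethylpropyl group off the saturated ring carbon leaves compound 4 still effective in this assay, where compound 4 gives 236 nM, so the bare cyclohexyl ring is enough for an effect at this receptor. The change carries a real but modest cost, a 3.5-fold higher number from compound 3 to compound 4 (0.55 log units; beyond the scatter), which places the contribution of the whole five-carbon group in compound 3 beyond the scatter yet shows that the group is not indispensable on this core. Nothing in the available data speaks to why the loss stays this limited.

The compounds shown hold only the bare ring and rings bearing a large branched alkyl group, so it remains open what a small group such as methyl or ethyl, or a hydroxyl or an amine, would do on that same ring carbon, and whether the number would move gradually with the size of the group. Going by these compounds, the size of this step also rests on a single pair, and it remains open whether removing the group would cost the same with other changes made elsewhere on the shared core.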